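The source may hold more compounds than are shown below. What is called first, only, known or untested is meant among the compounds shown, and "the series" means these compounds.

Compound 1, `CCOC(=O)/C(O)=C/C(=O)c1cn(Cc2ccc(F)cc2)c2ccc(OC)cc12`, gives 126000 nM in an ADME assay on MT4 cells (Homo sapiens) for cytotoxicity, read by MTT assay; on this read-out lower numbers stand for higher toxicity in this test and higher numbers for lower toxicity in this test.
Compound 2, `COc1cccc2c1c(C(=O)/C=C(\O)C(=O)O)cn2Cc1ccc(F)cc1`, gives 41100 nM in this assay.
Compound 3, `CCOC(=O)/C(O)=C/C(=O)c1cn(Cc2ccc(F)cc2)c2cccc(OC)c12`, gives 74000 nM in this assay.

Compound 3 and compound 2 differ in one place, (hydrogen in place of ethyl on an oxygen next to a carbonyl group), and the step between them, a 1.8-fold lower number from compound 3 to compound 2 (0.26 log units; within the scatter), is a small one. Compound 4, `COc1ccc2c(c1)c(C(=O)/C=C(\O)C(=O)O)cn2Cc1ccc(F)cc1`, has not been measured yet; it arises from compound 1 by the same change, (hydrogen in place of ethyl on an oxygen next to a carbonyl group). Compound 1 and compound 3 are built from the same atoms joined differently, and the difference between the two cores is not broken down here. Because the step of a 1.8-fold lower number from compound 3 to compound 2 (0.26 log units; within the scatter) stays within the scatter, a similarly small step is expected in this assay, a 1.8-fold lower number from compound 1 to compound 4 (0.26 log units; within the scatter). Compound 4 is therefore estimated at 70000 nM, with a likely range from 30000 nM to 160000 nM.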

Compound 4, half-maximal cytotoxic concentration: 63600 nM
Compound 4: the middle estimate sits 1.1-fold (0.04 log units) above what was measured; low and high end bracket the measured number.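

Replacing the ethyl on the ester oxygen with hydrogen, which turns ethoxycarbonyl into carboxy, gives a 2.0-fold lower number from compound 1 to compound 4 (0.30 log units; within the scatter), and in this assay this step compares with the earlier one on the other core as follows: the same change on two cores in this assay, a 1.8-fold lower number (0.26 log units; within the scatter) from compound 3 to compound 2 and a 2.0-fold lower number (0.30 log units; within the scatter) from compound 1 to compound 4, 1.1-fold (0.04 log units) apart, within the scatter of two such steps. On these two cores, then, the change carries over with a similarly small step. This does not show that it would behave alike on further cores, and as both steps lie within the scatter, neither alone can be told apart from the differences seen between repeated measurements.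

The compounds shown leave open what other groups on that oxygen would give, such as methyl or a longer chain like butyl. Going by these compounds, the effect of an amide in place of the ester also remains open.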